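The source may report more compounds than this note shows. Statements on the series, on what has been measured and on what is new or still open speak of the compounds shown alone.

In an assay on microsomes from brain for inhibition of Fatty-acid amide hydrolase 1 (Rattus norvegicus), read by fluorescence and HPLC, with a stated time of 60 min (a lower number here means a stronger inhibitor, a higher number a weaker inhibitor), three compounds built on one shared core have been measured. Compound 1 `CCCCCCCCc1ccc(OCC(=O)Cn2nnc(-c3ccncc3)n2)cc1` gives 24 nM, compound 2 `CCCCCCCCc1ccc(OCC(=O)Cn2nnc(Cc3ccccc3)n2)cc1` gives 66 nM, and compound 3 `CCCCCCCCc1ccc(OCC(=O)Cn2nnc(C(=O)O)n2)cc1` gives 41 nM. Compound 3 has the second highest of the three numbers; its nearest neighbour is compound 2, with a 1.6-fold lower number from compound 2 to compound 3 (0.21 log units; within the scatter), and its furthest is compound 1, with a 1.7-fold higher number from compound 1 to compound 3 (0.23 log units; within the scatter), so on these numbers compound 3 is not set apart from either. Going by the values given here, the only step beyond the scatter is a 2.8-fold higher number from compound 1 to compound 2 (0.44 log units; beyond the scatter). Compound 4 `CCCCCCCCc1ccc(OCC(=O)Cn2nnnc2C(=O)OC)cc1` differs from compound 3 in one place: 5-(methoxycarbonyl)-1H-tetrazol-1-yl in place of 5-carboxy-2H-tetrazol-2-yl on a saturated chain carbon bound to a carbonyl carbon. Among the compounds with values here, all three measured steps swap the group carried by the five-membered aromatic ring while keeping that ring joined to the chain in the same way, so none of them directly tests this change; they show only that swapping that group moves this assay by small amounts. The expectation is therefore a step of a 1.2-fold higher number from compound 3 to compound 4 (0.09 log units; within the scatter), that is nothing beyond the scatter. Compound 4 is estimated at 50 nM, with a range from 15 nM to 170 nM.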

Compound 4, half-maximal inhibitory concentration: 1000 nM
The estimate for compound 4 lay 20-fold (1.30 log units) below the measured number, outside the stated range (above it).
By their numbers in this assay, from the lowest: compounds 1, 3 and 2 (each within the scatter of the next, the first and the last beyond it); then compound 4.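

In this assay, the position on a saturated chain carbon bound to a carbonyl carbon proves far less tolerant of this change than the earlier swaps suggested: replacing 5-carboxy-2H-tetrazol-2-yl with 5-(methoxycarbonyl)-1H-tetrazol-1-yl gives a 24-fold higher number from compound 3 to compound 4 (1.39 log units; beyond the scatter) and leaves compound 4 well apart from the other three. Unlike those swaps, this change alters two things at once, turning the carboxy group into a methoxycarbonyl group and the tetrazol-2-yl attachment into a tetrazol-1-yl attachment. Nothing available here accounts for the size of this step.

The compounds shown leave open which of the two alterations matters, or whether only the pair together does. A 5-(methoxycarbonyl)-2H-tetrazol-2-yl group or a 5-carboxy-1H-tetrazol-1-yl group at this same position would separate them.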